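A Chlorine Added Twice: From Compound 1 to Compound 4

The source may hold more compounds than are shown below. What is called first, only, known or untested is meant among the compounds shown, and "the series" means these compounds.

Compound 1 `Cn1c(SCC(=O)Nn2c(COc3ccc(Cl)cc3Cl)nc3ccccc3c2=O)nc(-c2ccccc2)c(C#N)c1=O` and compound 2 `Cn1c(SCC(=O)Nn2c(COc3ccc(Cl)cc3Cl)nc3ccccc3c2=O)nc(-c2ccc(Cl)cc2)c(C#N)c1=O` share one core. In a functional assay on the whole organism (strain albino) for inhibition, with Rattus norvegicus as the target, read by paw edema, with stated times of 1 h and 3 h, at a dose of 100 mg/kg by the oral route (a lower number here means a weaker effect, a higher number a stronger effect of the compound at the dose given), compound 1 gives 59.7%, and compound 2 gives 73.7%. The change between them is chloro in place of hydrogen on an aromatic carbon, and it gave a number 14 percentage points higher from compound 1 to compound 2 (beyond the scatter). Compound 3 `N#Cc1c(Nc2ccccc2)nc(SCC(=O)Nn2c(COc3ccc(Cl)cc3Cl)nc3ccccc3c2=O)nc1-c1ccc(Cl)cc1` rests on a different core, and the difference between the two cores is not broken down here. In this assay compound 3 gives 56.1%. Compound 4 `N#Cc1c(Nc2ccc(Cl)cc2)nc(SCC(=O)Nn2c(COc3ccc(Cl)cc3Cl)nc3ccccc3c2=O)nc1-c1ccc(Cl)cc1` has not yet been measured; it carries the same change as before, (chloro in place of hydrogen on an aromatic carbon), which read one bond further out is anilino to (4-chlorophenyl)amino. The step from compound 3 to compound 4 is expected to be a number 9.9 percentage points higher from compound 3 to compound 4 (within the scatter), because the earlier step of a number 14 percentage points higher from compound 1 to compound 2 (beyond the scatter) came from the same change. Compound 4 is therefore estimated at 66%, expected to lie between 52% and 80%.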

Compound 4, a percentage reported as inhibition, in the whole organism at one dose (the size of the read-out at that dose, not a potency): 64.9%
Compound 4: the middle estimate sits 1.1 percentage points above what was measured; the range from low to high includes it.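

In this assay chloro in place of hydrogen on an aromatic carbon gave a number 8.8 percentage points higher from compound 3 to compound 4 (within the scatter) and so, taken alone, this step cannot be told apart from repeat-measurement noise. Set beside the earlier step on the other core, it does not differ measurably: the same change on two cores in this assay, a number 14 percentage points higher (beyond the scatter) from compound 1 to compound 2 and a number 8.8 percentage points higher (within the scatter) from compound 3 to compound 4, 5.2 percentage points apart, within the scatter of two such steps. This agrees with the change carrying over from one core to the other, but two pairs of compounds cannot establish a rule for the series or show that the two steps are truly equal.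

The compounds shown leave open whether fluoro, methoxy or a carboxylic acid in place of the chloro would behave the same way. They also leave open whether the same change would carry over to a third core.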